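This account rests on a few compounds, and the source may have more. Where it says the series, first, only, none or still open, it means among the compounds named here.

In a functional assay on NCI-H630 cells (Homo sapiens) for cytotoxicity, read by sulforhodamine B assay, with a stated time of 5 days (on this read-out higher numbers stand for weaker inhibition and lower numbers for stronger inhibition), compound 1 `O=C(CCCCc1ccccc1)CC(=O)N[C@H]1CCOC1=O` stands only at a limit, > 100000 nM. Compound 2 `O=C(CCCc1ccccc1)N[C@H]1CCOC1=O` likewise gives only a limit, > 100000 nM. Compound 3 `O=C(CCCc1ccccc1)CC(=O)N[C@H]1CCOC1=O` also gives only a limit, > 100000 nM. The evidence so far is therefore (the limit of > 100000 nM in this assay, at which 3 of the 3 values shown sit). The change leading to compound 4 `O=C(CCCCCc1ccccc1)CC(=O)N[C@H]1CCOC1=O` is benzyl in place of phenyl on a saturated chain carbon, four bonds along the chain from a carbonyl carbon. Going by the values given here, the one measured step that bears on it, a step that the two limits leave unreadable from compound 1 to compound 3, is the reverse kind of swap and has no readable size or direction. No step beyond the scatter is therefore expected in this assay. The expected step is a number no higher from compound 1 to compound 4 (the limit leaves the size open). For compound 4 the estimated value is 100000 nM, with an expected range from 40000 nM to 200000 nM.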

Compound 4, half-maximal inhibitory concentration: 44000 nM
Compound 4: the middle estimate sits 2.3-fold (0.36 log units) above what was measured; measured number inside the range.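

In this assay, benzyl in place of phenyl on a saturated chain carbon, four bonds along the chain from a carbonyl carbon, gives an at least 2.2-fold lower number from compound 1 to compound 4 (0.35 log units; beyond the scatter). This position therefore responds to the change, and compound 4 is the only compound shown with a measured number. The true size of the step stays open, since the other compounds give only a limit: the limit of > 100000 nM in this assay, at which 3 of the 4 values shown sit.

The compounds shown leave open whether a longer chain would lower the number further. They also leave open whether an amine in place of the benzyl would keep this cytotoxicity.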